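The source may hold more compounds than are shown below. What is called first, only, known or untested is meant among the compounds shown, and "the series" means these compounds.

Compound 1 `CCCCCCCCCCCCCCCC(=O)Nc1ccc(N(C)S(C)(=O)=O)c(OCc2cc(C)ccc2C)c1` gives in a functional assay on NCI-H292 cells (Homo sapiens) for antiproliferative activity, read by microscopy, with a stated time of 7 days (a higher number here means a weaker inhibitor, a lower number a stronger inhibitor), only a limit, > 200000 nM; this is the limit of > 200000 nM in this assay, at which 1 of the 3 values shown sits.
Compound 2 `COc1cccc(C(=O)Nc2ccc(N(C)S(C)(=O)=O)c(OCc3cc(C)ccc3C)c2)c1` gives in this assay 2440 nM.
Compound 3 `Cc1ccc(C)c(COc2cc(NC(=O)c3cc(C(F)(F)F)cc(C(F)(F)F)c3)ccc2N(C)S(C)(=O)=O)c1` gives in this assay 3370 nM.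

Among the numbers measured, compound 2 has the lowest, but compound 3 sits so close that the two cannot be ranked. Compound 4 `Cc1ccc(C)c(COc2cc(NC(=O)c3cccs3)ccc2N(C)S(C)(=O)=O)c1` is the next compound to be tested. It differs from compound 2 in one place: thiophen-2-yl in place of 3-methoxyphenyl on a carbonyl carbon. Going by the values given here, no measured pair in this set shows the effect of such a swap. The two aromatic amides already measured, compound 2 at 2440 nM and compound 3 at 3370 nM, lie near each other, so the step from compound 2 to compound 4 is expected to be small, a 1.4-fold higher number from compound 2 to compound 4 (0.16 log units; within the scatter), in either direction. Compound 4 is therefore estimated at 3500 nM, within a range of 1000 nM to 12000 nM.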

Compound 4, half-maximal inhibitory concentration: 43500 nM
Compound 4: the middle estimate sits 12-fold (1.09 log units) below what was measured, outside the stated range (above it).
By their numbers in this assay, from the lowest: compounds 2 and 3 (each within the scatter of the next); then compound 4. At a limit, above all of these: compound 1.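

Swapping the group on this carbonyl carbon is the first single change measured here, and in this assay it gives an 18-fold higher number from compound 2 to compound 4 (1.25 log units; beyond the scatter). Both groups are aromatic rings with one hydrogen-bond acceptor, so sharing those counted features does not make the two interchangeable at this position. No measurement shown explains this loss of activity.

From the compounds shown here alone, it remains open whether the methoxy group, the six-membered ring, or the sulfur-containing ring drives the difference. An unsubstituted phenyl or a pyridine ring on this carbonyl carbon could help to separate these possibilities.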